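The compounds below may be only part of what the source reports. "The series", "measured", "known", "first", "only" and "open" are said of these compounds alone.

Working notes on the series

The series shares one core; compound 1 is `CCCCCCNC(=O)c1cc(/C=C\c2cc(O)ccc2O)ccc1O` and compound 3 is `CCCCCCNC(=O)c1cc(CCc2cc(O)ccc2O)ccc1O`, both carrying free hydroxyl groups. In a functional assay on SF-539 cells (Homo sapiens) for antiproliferative activity (on this read-out lower numbers stand for stronger inhibition of growth and higher numbers for weaker inhibition of growth), compound 1 gives 3300 nM. Among the measured compounds shown here, compound 3 gives 2200 nM in this assay, and no step between compound 1 and compound 3 is worked out here; their two numbers simply stand side by side. Compound 2 is `CCCCCCNC(=O)c1cc(C#Cc2cc(OC)ccc2OC)ccc1OC`, the fully methylated member with an alkyne linker. In this assay compound 2 returns only a limit, > 100000 nM, and not a number. For the measured compounds named here, compound 2 therefore stands at the limit of > 100000 nM in this assay, at which 1 of the 3 values shown sits, with no measured step leading to or from it.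

The step under consideration leads from compound 2 to compound 4, which is `COC(=O)c1cc(C#Cc2cc(OC)ccc2OC)ccc1OC` and still awaits measurement in this assay. The counted difference is methoxy in place of hexylamino on a carbonyl carbon; the hexylamino group leaves and a methoxy group enters on the carbonyl carbon, so the amide becomes an ester while every other part of compound 2 stays as it is.

Going by the values given here, no measured step is available for this change, and compound 2 itself provides only a limit. The expectation is that compound 4 remains in the same region, so the step from compound 2 to compound 4 is estimated as a step that the limit leaves unreadable from compound 2 to compound 4, with no shift beyond the scatter anticipated. For compound 4 the estimate in this assay is 120000 nM, with a range from 30000 nM to 500000 nM, and a limit rather than a number is the most likely outcome.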

Compound 4, concentration for 50% growth inhibition: 81100 nM
Compound 4: middle estimate off by 1.5-fold (0.17 log units), on the high side; the measured number falls inside the stated range.
By their numbers in this assay, from the lowest: compounds 3 and 1 (each within the scatter of the next); then compound 4. At a limit, above all of these: compound 2.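

In this assay compound 4 gives 81100 nM, a real number, so the fully methylated alkyne member still gives a readable value when a methoxy group replaces hexylamino on the carbonyl carbon, and the hexylcarbamoyl group is not needed for a number on this read-out. Methoxy in place of hexylamino on a carbonyl carbon gives an at least 1.2-fold lower number from compound 2 to compound 4 (0.09 log units; that floor lies within the scatter), so this pair shows a floor for the step and not a demonstrated change beyond the scatter. The full size of the step cannot be read because compound 2 carries a limit and not a number: the limit of > 100000 nM in this assay, at which 1 of the 4 values shown sits.

Still open, from the compounds shown here alone, is how other groups on the same carbonyl carbon would read in this assay, for example a carboxylic acid, or an amine with a chain shorter or longer than hexyl, which would show whether the chain on the amide matters at all. Also open, going by these compounds, is whether hexylcarbamoyl to methoxycarbonyl reads the same way on the members with free hydroxyl groups, where the values lie in a different part of the scale.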